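The source may hold more compounds than are shown below. What is called first, only, known or untested is meant among the compounds shown, and "the series" means these compounds.

Within the data shown here, compound 1, with the structure `O=C(O)c1csc([C@H]2CC[C@@H]3[C@@H](/C=C/COc4ccccc4)[C@H](O)C[C@@H]3O2)n1`, is the only member of this small set with a number attached to it. In a functional assay on CHO cells for agonist activity at prostaglandin E2 receptor EP3 subtype (Homo sapiens), read by fluorescence and calcium flux (a lower number here means that less compound is needed, a higher number that more compound is needed for the effect), compound 1 gives 7600 nM, a value that marks it as a weak agonist on this read-out. A related compound, compound 2, with the structure `O=C(O)c1csc([C@H]2CC[C@@H]3[C@@H](CCCCCOc4ccccc4)[C@H](O)C[C@@H]3O2)n1`, carries a fully saturated chain in place of the double bond, but in this assay compound 2 gives "not determined" (no result reported), so it adds nothing to the picture in numbers.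

Compound 3, with the structure `O=C(O)c1csc([C@H]2CC[C@@H]3[C@@H](/C=C/CCOc4ccccc4)[C@H](O)C[C@@H]3O2)n1`, has not yet been measured. It differs from compound 1 in a single place: phenoxymethyl in place of phenoxy on a saturated chain carbon bound to a double-bonded chain carbon. The shared core, the acid-bearing head group and the double bond are all kept; only the tail that carries the aromatic ring is lengthened.

Without any measured pair showing what such a lengthening does, the expectation rests on compound 1 alone. The step from compound 1 to compound 3 is expected to be small, a 1.3-fold lower number from compound 1 to compound 3 (0.10 log units; within the scatter), not clearly beyond the usual scatter in either direction. Compound 3 is therefore expected to give roughly 6000 nM in this assay, with a plausible range from 1500 nM to 25000 nM.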

Compound 3, half-maximal effective concentration: 260 nM
The estimate for compound 3 lay 23-fold (1.36 log units) above the measured number; the whole stated range lies above it.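

In this assay, moving from phenoxy to phenoxymethyl on a saturated chain carbon bound to a double-bonded chain carbon gives a 29-fold lower number from compound 1 to compound 3 (1.47 log units; beyond the scatter), a large step and the first sign that this position responds strongly to the length of the tail. The change itself is slight: the count goes from 7 to 8 heavy atoms, while the aromatic ring, the oxygen, the absence of hydrogen-bond donors and the absence of net charge all stay the same, so even a very small extension of this tail can matter greatly on this read-out. No supporting information is available to explain why so modest a change has so large an effect.

From the compounds shown here alone, one lengthening gives a single step and not a trend, so it remains open whether a still longer chain ending in the same phenoxy group would lower the number further, leave it unchanged or raise it again. The compounds shown also give no usable comparison for the double bond, and they leave open what an amine in place of the chain oxygen would do.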